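From an Acid-Bearing Chain to a Charged Chain

The source may report more compounds than this note shows. Statements on the series, on what has been measured and on what is new or still open speak of the compounds shown alone.

The measured compounds:
- compound 1 `COc1ccc2c(=O)cc(-c3ccc(O)c(O)c3)oc2c1` gives 2500 nM
- compound 2 `C[N+](C)(C)CCCOc1ccc2c(=O)cc(-c3ccc(O)c(O)c3)oc2c1` gives 37300 nM
- compound 3 `O=C(O)COc1c(-c2ccc(O)c(O)c2)oc2ccccc2c1=O` gives 6500 nM

All three numbers come from a functional assay for inhibition, with Rattus norvegicus as the target, using microsomes; on this read-out lower numbers stand for stronger inhibition and higher numbers for weaker inhibition. On these numbers compound 3 stands second highest of the three: compound 1 sits below it, and compound 2 sits above it.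

Compound 4 `C[N+](C)(C)CCCCCCOc1c(-c2ccc(O)c(O)c2)oc2ccccc2c1=O` is not yet measured. It differs from compound 3 in one place: a group of 9 heavy atoms (8 carbon, 1 nitrogen; no ring) in place of a group of 3 heavy atoms (1 carbon, 2 oxygen; no ring), on a saturated chain carbon bound to an oxygen on an aromatic ring. The carboxy group leaves and a long chain ending in a positively charged nitrogen enters.

Among the compounds with values here, only one measured step speaks to this. Going a 15-fold higher number from compound 1 to compound 2 (1.17 log units; beyond the scatter), where a similar charged chain entered, the number rose strongly. Compound 4 adds a longer charged chain and at the same time loses the carboxy group; nothing measured shows what the loss of that group alone does. The expectation is therefore a clearly higher number in this assay, of a size near the step from compound 1 to compound 2, written as a 6.9-fold higher number from compound 3 to compound 4 (0.84 log units; beyond the scatter). Compound 4 is estimated at 45000 nM, within 12000 nM to 170000 nM.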

Compound 4, half-maximal inhibitory concentration: 1400 nM
Compound 4: middle estimate off by 32-fold (1.51 log units), on the high side; measured number below the stated range.
By their numbers in this assay, from the lowest: compounds 4 and 1 (each within the scatter of the next); then compound 3; then compound 2.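

In this assay, swapping the carboxy group for the long chain ending in a positively charged nitrogen, on a saturated chain carbon bound to an oxygen on an aromatic ring, gives a 4.6-fold lower number from compound 3 to compound 4 (0.67 log units; beyond the scatter) and so shows that a charged chain at this place can go with a lower number. The earlier step, a 15-fold higher number from compound 1 to compound 2 (1.17 log units; beyond the scatter), ran the other way, so a charged chain brings no single direction of change across these compounds, though those two steps differ in both core and chain. Nothing measured here gives a reason for this result.

The compounds shown leave open whether the change follows from the carboxy group leaving or from the new chain entering. A shorter chain ending in the same charged nitrogen, or a chain of equal length ending in an amine, would help to separate chain length from the charged end.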